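This account rests on a few compounds, and the source may have more. Where it says the series, first, only, none or still open, it means among the compounds named here.

In a functional assay on MNK45 cells (Homo sapiens) for inhibition, read by MTT assay, with a stated time of 48 h (on this read-out higher numbers stand for weaker inhibition and lower numbers for stronger inhibition), compound 1, `Cc1ccc(NC(=S)NC(=O)c2ccc(OCc3ccccc3Cl)cc2)cc1-c1nc2ccccc2[nH]1`, gives 51400 nM, and compound 2, `Cc1ccc(NC(=O)NC(=O)c2ccc(OCc3cccc(Cl)c3)cc2)cc1-c1nc2ccccc2[nH]1`, gives 28000 nM. Compound 2 has the lower of the two numbers shown, yet compound 1 sits within the usual scatter of it, so the two cannot be told apart. Compound 3, `Cc1ccc(NC(=O)NC(=O)c2ccc(OCc3cccc(Cl)c3Cl)cc2)cc1-c1nc2ccccc2[nH]1`, has not been measured; it differs from compound 2 by chloro in place of hydrogen on an aromatic carbon. Within the data shown here, with no comparable step among the measured compounds, the expected change from compound 2 to compound 3 in this assay is a 1.1-fold lower number from compound 2 to compound 3 (0.05 log units; within the scatter), not beyond the scatter. Compound 3 is therefore estimated at 25000 nM, between 8000 nM and 80000 nM.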

Compound 3, half-maximal inhibitory concentration: 87000 nM
Beside the measured number, compound 3's estimate is 3.5-fold (0.54 log units) below it; the measured number lies above the stated range.
By their numbers in this assay, from the lowest: compounds 2, 1 and 3 (each within the scatter of the next, the first and the last beyond it).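

In this assay, turning the 3-chlorobenzyl group into the 2,3-dichlorobenzyl group gives a 3.1-fold higher number from compound 2 to compound 3 (0.49 log units; beyond the scatter) and so weakens inhibition. This aromatic carbon, ortho to a chloro group, is therefore not indifferent to what it carries: one added chlorine atom is enough for a change beyond the scatter, although this rests on a single pair. Nothing measured here explains the change. Going by these compounds, whether fluoro, methyl or an amine on this same carbon would also weaken inhibition remains open, and so does whether hydrogen is the best choice here.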